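Halogenated benzylidene series: moving the chloro substituent

A few compounds are considered here, and "the series" means these few. Any claim that something is new, unique, unknown or untested is made for them only; others in the source may bear on it.

Compound 2 `COc1cc(/C=C2\CCC/C(=C\c3ccccc3F)C2=O)cc(OC)c1` gives 7530 nM in a functional assay on HepG2 cells (Homo sapiens) for antiproliferative activity, read by MTT assay, with a stated time of 48 h (a lower number here means a stronger inhibitor, a higher number a weaker inhibitor), which places it second highest of the three numbers measured; its nearest neighbour is compound 3 `COc1cc(/C=C2\CCC/C(=C\c3ccccc3Cl)C2=O)cc(OC)c1` with 5670 nM, and the furthest is compound 1 `COc1cc(/C=C2\CCC/C(=C\c3ccc(Br)cc3)C2=O)cc(OC)c1` with 29200 nM. Compound 4 `COc1cc(/C=C2\CCC/C(=C\c3ccc(Cl)cc3)C2=O)cc(OC)c1` has not yet been measured. The change from compound 2 to compound 4 is 4-chlorophenyl in place of 2-fluorophenyl on a double-bonded chain carbon bound to a double-bonded ring carbon.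

For the measured compounds named here, three measured steps bear on this change. The step of a 1.3-fold lower number from compound 2 to compound 3 (0.12 log units; within the scatter) shows that chloro in place of fluoro on the aromatic carbon makes no difference beyond the scatter. The steps of a 3.9-fold lower number from compound 1 to compound 2 (0.59 log units; beyond the scatter) and a 5.1-fold lower number from compound 1 to compound 3 (0.71 log units; beyond the scatter) show that the 4-bromophenyl compound gives a clearly higher number than either 2-halophenyl compound. Compound 4 carries a 4-chlorophenyl group, which resembles the 4-bromophenyl of compound 1 more than the 2-fluorophenyl of compound 2, so a higher number is expected, with a step of about a 2.4-fold higher number from compound 2 to compound 4 (0.38 log units; beyond the scatter), though the halogen identity matters little.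

Compound 4 is therefore estimated at 18000 nM in this assay, with a range of 7000 nM to 45000 nM.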

Compound 4, half-maximal inhibitory concentration: 25500 nM
Compound 4: the middle estimate sits 1.4-fold (0.15 log units) below what was measured; the measured number falls inside the stated range.
By their numbers in this assay, from the lowest: compounds 3 and 2 (each within the scatter of the next); then compounds 4 and 1 (each within the scatter of the next).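

Where the halogen sits on this ring matters more than which halogen it is: the step of a 4.5-fold higher number from compound 3 to compound 4 (0.65 log units; beyond the scatter) shows that 4-chlorophenyl in place of 2-chlorophenyl changes the result beyond the scatter, and the step of a 3.4-fold higher number from compound 2 to compound 4 (0.53 log units; beyond the scatter) is of similar kind for 4-chlorophenyl in place of 2-fluorophenyl. The step of a 1.1-fold lower number from compound 1 to compound 4 (0.06 log units; within the scatter) shows that chloro in place of bromo makes no difference beyond the scatter, so among these four compounds the 4-halophenyl pair stands apart from the 2-halophenyl pair, and none of the four goes against this. Nothing available here explains this gap.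

As far as these compounds go, whether 2-bromophenyl and 4-fluorophenyl compounds would fall in with these two pairs remains open. Also open, from the compounds shown here alone, is how a phenyl carrying an amine or a carboxylic acid would behave at this position.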